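A Trifluoromethoxy Step Expected to Lower Compound 1's Number

The compounds below may be only part of what the source reports. "The series", "measured", "known", "first", "only" and "open" are said of these compounds alone.

Among the compounds with values here, in a functional assay on HCT-116 cells (Homo sapiens) for antiproliferative activity, read by MTT assay, with a stated time of 72 h (on this read-out lower numbers stand for stronger inhibition and higher numbers for weaker inhibition), compound 1 `O=C(CCc1cccc2c1B(O)OC2)Nc1cccc(-c2ccccc2)c1` gives 890 nM, the highest of the three numbers measured so far. Compound 2 `O=C(CCc1cccc2c1B(O)OC2)Nc1cccc(-c2cccc(Cl)c2)c1` gives 350 nM, and compound 3 `O=C(CCc1cccc2c1B(O)OC2)Nc1cccc(-c2cccc(OC(F)(F)F)c2)c1` gives 310 nM. Adding chloro produces a 2.5-fold lower number from compound 1 to compound 2 (0.41 log units; beyond the scatter), while adding trifluoromethoxy produces a 2.9-fold lower number from compound 1 to compound 3 (0.46 log units; beyond the scatter). These two analogues cannot be separated, as the remaining comparison is a 1.1-fold lower number from compound 2 to compound 3 (0.05 log units; within the scatter).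

Compound 4 `O=C(CCc1cccc2c1B(O)OC2)Nc1cccc(-c2ccc(OC(F)(F)F)cc2)c1`, not yet measured, keeps the core of compound 1 and makes one change: trifluoromethoxy in place of hydrogen on an aromatic carbon. Trifluoromethoxy replaces hydrogen on an aromatic carbon of a six-membered aromatic ring of carbon only, para to a large group.

Within the data shown here, the closest precedent is a 2.9-fold lower number from compound 1 to compound 3 (0.46 log units; beyond the scatter), which carries the same group on another carbon of that ring. The chloro result, a 2.5-fold lower number from compound 1 to compound 2 (0.41 log units; beyond the scatter), is of similar modest size and runs in the same direction. Among the measured compounds shown here, no measured compound carries a group at the new place, so the data do not show whether the effect transfers. A modest move toward a lower number in this assay is therefore expected, though a step within the scatter would not be surprising. The expected step is a 2.2-fold lower number from compound 1 to compound 4 (0.35 log units; beyond the scatter). Compound 4 is estimated at 400 nM, with an expected range from 170 nM to 950 nM.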

Compound 4, half-maximal inhibitory concentration: 730 nM
For compound 4 the middle estimate is 1.8-fold (0.26 log units) below the measured one, and the stated range covers the measured number.
By their numbers in this assay, from the lowest: compounds 3 and 2 (each within the scatter of the next); then compounds 4 and 1 (each within the scatter of the next).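

In this assay, trifluoromethoxy on an aromatic carbon para to a large group does not repeat the gain that the same group gave on another carbon of that ring: the step is a 1.2-fold lower number from compound 1 to compound 4 (0.09 log units; within the scatter) and leaves compound 4 indistinguishable from compound 1. Within the data shown here, the earlier compounds showed only that adding a group to this ring could lower the number, whereas the same group now gives different outcomes at two places, with compound 3 at 310 nM and compound 4 at 730 nM in the same assay, so the place matters here as well as the group. Nothing shown accounts for this difference between the two places.

The compounds shown leave open whether chloro at this para place would behave as trifluoromethoxy does here, or would keep the lower number seen with compound 2. They also leave open whether a different group at this place, such as an amine or a carboxylic acid, would move the number beyond the scatter from compound 1 in either direction.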